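The compounds below may be only part of what the source reports. "The series", "measured", "known", "first", "only" and "open" are said of these compounds alone.

Working notes on the series.

Three compounds have been run in a functional assay on HT-29 cells (Homo sapiens) for cytotoxicity, read by sulforhodamine B assay, with a stated time of 2 days, tested at 100 uM; a higher number here means more inhibition at the concentration tested (going by the name of the read-out), a lower number less inhibition. Compound 1 `O=C(Nn1c(-c2cccc([N+](=O)[O-])c2)nc2c(-c3cccs3)n[nH]c2c1=O)c1cccnc1` gives 3.9%. Compound 2 `O=C(Nn1c(-c2cccc([N+](=O)[O-])c2)nc2c(CCc3ccccc3)n[nH]c2c1=O)c1ccccc1` gives 89.7%, and compound 3 `COc1cccc(Cc2nc3c(-c4ccc(Cl)cc4)n[nH]c3c(=O)n2NC(=O)c2ccccc2)c1` gives 89.3%. Compound 3 stands second highest of the three; its nearest neighbour is compound 2, within the scatter, and its furthest is compound 1, beyond the scatter. For the measured compounds named here, compounds 1, 2 and 3 each differ in more than one place, so no single step can be drawn between them.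

The next compound, compound 4 `CCCCCc1nc2c(-c3ccc(Cl)cc3)n[nH]c2c(=O)n1NC(=O)c1ccccc1`, differs from compound 3 in one place: butyl in place of 3-methoxyphenyl on a saturated chain carbon bound to an aromatic carbon. Cut one bond further out, the change reads 3-methoxybenzyl to pentyl. Going by the values given here, no measured pair shows the effect of such an exchange; compounds 2 and 3 both carry a ring at that side and both sit high in this assay, while compound 1, the low point, differs elsewhere.

The step from compound 3 to compound 4 is expected to be downward and possibly beyond the scatter, a number 19.3 percentage points lower from compound 3 to compound 4 (beyond the scatter), with wide uncertainty. Compound 4 is estimated at 70%, in a range from 25% to 95%.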

Compound 4, a percentage reported as inhibition, at one concentration (the size of the read-out at that concentration, not a potency): 90.1%
Compound 4: middle estimate off by 20.1 percentage points, on the low side; low and high end bracket the measured number.
By their numbers in this assay, from the lowest: compound 1; then compounds 3, 2 and 4 (each within the scatter of the next).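

In this assay, butyl in place of 3-methoxyphenyl on a saturated chain carbon bound to an aromatic carbon gives a number 0.8 percentage points higher from compound 3 to compound 4 (within the scatter). For this pair, the second aromatic ring and its methoxy oxygen can therefore be exchanged for an open carbon chain with no change beyond the scatter, even though the group entering has fewer heavy atoms and no ring. No measured property bears on this result.

On these data alone, whether a shorter chain such as ethyl, or an amine or a carboxylic acid in place of butyl, would hold the number at this position remains open, and a single-concentration read-out could hide differences in potency between compound 3 and compound 4. Compound 1 gives 3.9%, but it differs from the others in more than one place, so that low number cannot be tied to any single change.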